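Alpha-1D agonist series: replacing the thiophene on the shared core

A few compounds are considered here, and "the series" means these few. Any claim that something is new, unique, unknown or untested is made for them only; others in the source may bear on it.

Measured compounds:
compound 1, `Cc1ccsc1-c1ccccc1NCC1=NCCN1`, 49 nM
compound 2, `Cc1cccnc1-c1ccccc1NCC1=NCCN1`, < 100000 nM

In a functional assay for activation of Alpha-1D adrenergic receptor (Homo sapiens) (a lower number here means that less compound is needed, a higher number that more compound is needed for the effect), compound 1 gives 49 nM. For compound 2 the result is a limit of the assay, < 100000 nM, not a number; (the limit of < 100000 nM in this assay, at which 1 of the 2 values shown sits). Within the data shown here, compound 1 thus holds the only numerical value shown for this assay.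

Compound 3, `CC/C(=N\OC)c1ccccc1NCC1=NCCN1`, is not yet measured. Against compound 1 the change is a group of 6 heavy atoms (4 carbon, 1 nitrogen, 1 oxygen; no ring) in place of a group of 6 heavy atoms (5 carbon, 1 sulfur; one five-membered aromatic ring with 1 hetero atom), on an aromatic carbon, on an aromatic carbon of a six-membered aromatic ring of carbon only. Among the measured compounds shown here, no measured pair isolates this kind of change, so the step is unknown.

The expected step from compound 1 to compound 3 is a 12-fold higher number from compound 1 to compound 3 (1.09 log units; beyond the scatter), a loss beyond the scatter. For compound 3 the estimated value in this assay is 600 nM, with a range from 100 nM to 5000 nM.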

Compound 3, half-maximal effective concentration: < 100000 nM
Compound 3: a limit, no number (the forecaster's own chance of this, stated with the estimate: 10%); the middle value is on the limit's open side.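

Among these compounds, compound 3 gives a limit in this assay, < 100000 nM, not a number, and no step from compound 1 to compound 3 can be read. The compounds shown leave open whether any group other than 3-methylthiophen-2-yl on the shared core gives a numerical value.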